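The compounds below may be only part of what the source reports. "The series", "measured", "known", "first", "only" and "open" are said of these compounds alone.

Working notes on the series, read in a functional assay on cells (Lymphocyte, Homo sapiens) for cytotoxicity (a lower number here means that less compound is tolerated, a higher number that more compound is tolerated), as the only assay at hand. Compound 1 `Cc1cc(C)cc(S(=O)(=O)c2c(C(=O)NN3CCOC3=O)[nH]c3ccc(Cl)cc23)c1` gives > 100 uM as a limit and not a number. Compound 2 `CNNC(=O)c1[nH]c2ccc(Cl)cc2c1S(=O)(=O)c1cc(C)cc(C)c1` gives > 100 uM as a limit as well. Compound 3 `Cc1cc(C)cc(S(=O)(=O)c2c(C(=O)NNC3CCCCC3)[nH]c3ccc(Cl)cc23)c1` gives > 100 uM as a limit too. Compound 3 therefore stands on the limit of > 100 uM in this assay, at which 3 of the 3 values shown sit, and has no number that would place it within the series.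

The step to compound 4 `CC(=O)NNC(=O)c1[nH]c2ccc(Cl)cc2c1S(=O)(=O)c1cc(C)cc(C)c1` is acetyl in place of cyclohexyl on an amine nitrogen and reads as cyclohexylamino to acetamido on the amine nitrogen. Three measured steps change the group at this end of the molecule. These are a step that the two limits leave unreadable from compound 1 to compound 2 and a step that the two limits leave unreadable from compound 1 to compound 3 and a step that the two limits leave unreadable from compound 2 to compound 3 in turn. None of them has a readable size, so no measured effect can be carried over. Going by the values given here, with a step that the two limits leave unreadable from compound 2 to compound 3 as the nearest precedent on the same amine nitrogen, no shift in either direction beyond the scatter is expected for compound 4 in this assay. The expected outcome is a step that the limit leaves unreadable from compound 3 to compound 4 with a reading in this assay that is most likely another limit. For compound 4 the estimate is 130 uM with an expected range from 50 uM to 300 uM in this series.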

Compound 4, half-maximal toxic concentration: > 100 uM
Compound 4 ended at the assay's limit; the forecaster's own chance of this, stated with the estimate: 85%; the middle value does not contradict the limit.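

The steps from compounds 1, 2 and 3 to compound 4 cannot be read, as all four compounds share one limit and give no numbers: the limit of > 100 uM in this assay, at which 4 of the 4 values shown sit.

The compounds shown leave open whether acetyl, cyclohexyl, methyl or the 2-oxo-1,3-oxazolidin-3-yl group differ at all in this assay.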